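From Isopropyl to Aminomethyl on a Shared Core

This account rests on a few compounds, and the source may have more. Where it says the series, first, only, none or still open, it means among the compounds named here.

Of the compounds shown here, three sharing one core have been measured in a toxicity assay on CCRF-CEM cells (Homo sapiens) for cytotoxicity; a higher number here means that more compound is tolerated, a lower number that less compound is tolerated. Compound 1 `Nc1cccc2c1nc(-c1c(F)cccc1F)n2Cc1c(F)cccc1F` gives 26.3 uM, compound 2 `CN(C)C(=O)c1cccc2c1nc(-c1c(F)cccc1F)n2Cc1c(F)cccc1F` gives 80.1 uM, and compound 3 `CC(C)c1cccc2c1nc(-c1c(F)cccc1F)n2Cc1c(F)cccc1F` gives 27 uM. Compound 3 therefore stands level with one neighbour, a 1.0-fold higher number from compound 1 to compound 3 (0.01 log units; within the scatter), and clearly below the other, a 3.0-fold lower number from compound 2 to compound 3 (0.47 log units; beyond the scatter).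

Next comes compound 4 `NCc1cccc2c1nc(-c1c(F)cccc1F)n2Cc1c(F)cccc1F`, in which aminomethyl takes the place of isopropyl on an aromatic carbon: aminomethyl in place of isopropyl on an aromatic carbon. Among the measured compounds shown here, no measured step makes this exact swap. The closest comparison is between the amino group of compound 1 and the isopropyl group of compound 3, and that exchange made no real difference, a 1.0-fold higher number from compound 1 to compound 3 (0.01 log units; within the scatter). The one clear rise, a 3.0-fold higher number from compound 1 to compound 2 (0.48 log units; beyond the scatter), brought in dimethylcarbamoyl, a group absent from compound 4.

In this assay, the expected step, a 1.1-fold lower number from compound 3 to compound 4 (0.03 log units; within the scatter), therefore stays within the scatter. The estimated value for compound 4 is 25 uM, with an expected range from 10 uM to 60 uM.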

Compound 4, half-maximal toxic concentration: 49.3 uM
The estimate for compound 4 lay 2.0-fold (0.29 log units) below the measured number, and the stated range covers the measured number.
By their numbers in this assay, from the lowest: compounds 1, 3, 4 and 2 (each within the scatter of the next, the first and the last beyond it).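

In this assay, replacing isopropyl, which has no hydrogen-bond donor or acceptor, with aminomethyl, which has one of each, on this aromatic carbon gives a step that stays inside the scatter (a 1.8-fold higher number from compound 3 to compound 4 (0.26 log units; within the scatter)), and the same holds for the change from amino (a 1.9-fold higher number from compound 1 to compound 4 (0.27 log units; within the scatter)). The change from dimethylcarbamoyl is also inside the scatter (a 1.6-fold lower number from compound 2 to compound 4 (0.21 log units; within the scatter)), so compound 4 cannot be told apart from any of the three earlier compounds, even though compound 2 stands clearly apart from compound 1 and compound 3. Nothing available here accounts for this result.

Going by these compounds, whether a carboxylic acid or a longer amine chain at this position would stand clearly apart from compound 4 remains open. On these data alone, how far this pattern holds on a different core also remains open.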